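The source may hold more compounds than are shown below. What is called first, only, known or untested is meant among the compounds shown, and "the series" means these compounds.

In an ADME assay on microsomes from liver (Homo sapiens) for metabolic stability, with a stated time of 30 min (a higher number here means that more of the compound is left, a lower number that less of the compound is left), compound 1 `O=C(O)[C@H](CO)NC(=O)N1CCCC1` stands as "not determined" (no result reported) and so offers no number to compare. Compound 2 `CN(C)C(=O)N[C@@H](CO)C(=O)O` gives 34% and holds the lower of the two numbers available, while compound 3 `CC(C)C(=O)N[C@@H](CO)C(=O)O` gives 84% in this assay as well.

Still unmeasured is compound 4 `O=C(N[C@@H](CO)C(=O)O)C1CC1`, which differs from compound 2 in one place. The change is cyclopropyl in place of dimethylamino on a carbonyl carbon and it puts cyclopropyl in place of dimethylamino on a carbonyl carbon.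

In this assay, going by the values given here, the one measured step that bears on this is isopropyl in place of dimethylamino on a carbonyl carbon. It shows a number 50 percentage points higher from compound 2 to compound 3 (beyond the scatter) and counts as large. Like cyclopropyl, isopropyl holds no nitrogen, so a clear rise is expected here too. Among the compounds with values here, still, the two groups are not the same, and this single step is the only guide, so the rise could well turn out smaller.

The expected step is a number 38 percentage points higher from compound 2 to compound 4 (beyond the scatter) and it would lie beyond the scatter. In this assay the estimate for compound 4 is 72% with an expected range from 50% to 92% for repeated measurements.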

Compound 4, percent of the compound remaining: 26%
The estimate for compound 4 lay 46 percentage points above the measured number; the measured number lies below the stated range.
By their numbers in this assay, from the lowest: compounds 4 and 2 (each within the scatter of the next); then compound 3.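

In this assay, cyclopropyl in place of dimethylamino gives a number 8 percentage points lower from compound 2 to compound 4 (within the scatter) on the carbonyl carbon, so these two groups cannot be told apart here, and a group without nitrogen at this place does not by itself bring a high number. The other new comparison is more striking, since cyclopropyl in place of isopropyl gives a number 58 percentage points lower from compound 3 to compound 4 (beyond the scatter) even though neither group holds nitrogen, which shows that two carbon-only groups at this one place can give very different results. Among the compounds with numbers, the high result therefore belongs to isopropyl in compound 3 alone, and no measured information on why these groups behave so differently is available.

The compounds shown leave open whether the high number is particular to isopropyl or also appears with other carbon groups at this place, such as ethyl, tert-butyl or a longer chain. They also leave open how a larger carbon ring, such as cyclobutyl or cyclohexyl, would compare with the small ring of compound 4.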